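From compound 1 to compound 4: methyl to benzyl

This account rests on a few compounds, and the source may have more. Where it says the series, first, only, none or still open, it means among the compounds named here.

Among the measured compounds shown here, in a physicochemical assay for solubility, read by HPLC, using the shake flask method, measured as kinetic solubility, with a stated time of 20 h, at pH 6.5, tested at 200 uM (a higher number here means a more soluble compound, a lower number a less soluble compound), compound 1 `CN1CCN(c2ccnc3ccc(-c4cccc(S(N)(=O)=O)c4)nc23)CC1` gives 200000 nM, the only true number so far. Compound 2 `NS(=O)(=O)c1cccc(-c2ccc3nccc(-c4cccnc4)c3n2)c1` gives < 5000 nM, which is a limit. Compound 3 `NS(=O)(=O)c1cccc(-c2ccc3nccc(-c4cn[nH]c4)c3n2)c1` gives < 5000 nM, also a limit.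

Compound 4 `NS(=O)(=O)c1cccc(-c2ccc3nccc(N4CCN(Cc5ccccc5)CC4)c3n2)c1` differs from compound 1 within the 4-methylpiperazin-1-yl group: phenyl in place of hydrogen on a saturated chain carbon bound to an amine nitrogen in a ring. The change reads as methyl to benzyl.

For the measured compounds named here, no measured step makes this exact change. The nearest evidence is the replacement of that whole group, with two large steps: an at least 40-fold lower number from compound 1 to compound 2 (1.60 log units; beyond the scatter) and an at least 40-fold lower number from compound 1 to compound 3 (1.60 log units; beyond the scatter). Compound 4 alters the group only in part, so a lower number is expected, though a smaller drop than those two. The expected step is an 8.0-fold lower number from compound 1 to compound 4 (0.90 log units; beyond the scatter). Compound 4 is estimated at 25000 nM, with an expected range of 5000 nM to 120000 nM.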

Compound 4, solubility: < 5000 nM
Compound 4 ended at the assay's limit (the forecaster's own chance of this, stated with the estimate: 30%); middle value at least 5.0-fold (0.69 log units) away from the limit.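

In this assay, methyl to benzyl alone, a change to only part of the 4-methylpiperazin-1-yl group, gives an at least 40-fold lower number from compound 1 to compound 4 (1.60 log units; beyond the scatter). Compound 4 gives < 5000 nM, which is a limit. Keeping the rest of that group is therefore not enough to stay clear of the limit, and only compound 1 now has a true number: the limit of < 5000 nM in this assay, at which 3 of the 4 values shown sit.

Going by these compounds, how far compound 4 lies past its limit remains unknown, so the step has only a floor. Also open, on these data alone, is whether ethyl in place of methyl, or a carboxylic acid on that saturated chain carbon, would stay clear of the limit.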